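This account rests on a few compounds, and the source may have more. Where it says the series, first, only, none or still open, it means among the compounds named here.

Measured in a functional assay on AGS cells (Homo sapiens) for inhibition, read by MTT assay, with a stated time of 72 h; on this read-out higher numbers stand for weaker inhibition and lower numbers for stronger inhibition:
Compound 1 `CC(=O)Oc1cc(C(=O)C2=C(O)[C@]3(CC=C(C)C)C[C@@H](C/C=C(\C)CCC=C(C)C)[C@](C)(CCC=C(C)C)[C@](CC=C(C)C)(C2=O)C3=O)ccc1O`: 8090 nM
Compound 2 `CC(=O)Oc1ccc(C(=O)C2=C(O)[C@]3(CC=C(C)C)C[C@@H](C/C=C(\C)CCC=C(C)C)[C@](C)(CCC=C(C)C)[C@](CC=C(C)C)(C2=O)C3=O)cc1OC(C)=O`: 15700 nM

Compound 1 and compound 2 lie within the scatter of each other, so neither can be ranked ahead of the other. Compound 3 `CC(C)=CCC/C(C)=C/C[C@@H]1C[C@]2(CC=C(C)C)C(=O)[C@@](CC=C(C)C)(C(=O)C(C(=O)c3ccc(O)c(OC(=O)CCCC[C@@H]4SCC5NC(=O)NC54)c3)=C2O)[C@@]1(C)CCC=C(C)C` comes from compound 1 by a single change: a group of 12 heavy atoms (8 carbon, 2 nitrogen, 1 oxygen, 1 sulfur; one five-membered non-aromatic ring with 1 hetero atom, one five-membered non-aromatic ring with 2 hetero atoms) in place of a hydrogen atom, on a saturated chain carbon bound to a carbonyl carbon. Within the data shown here, the only measured step with any bearing on this is a 1.9-fold higher number from compound 1 to compound 2 (0.29 log units; within the scatter). That step is a different change, an acetyl in place of a hydrogen on an oxygen on an aromatic ring, and it stayed within the scatter. Among the measured compounds shown here, no measured step covers a group like the one entering here, so the evidence is thin. In this assay no step beyond the scatter is therefore expected, in either direction, though the range has to stay wide. The estimated step is a 1.2-fold higher number from compound 1 to compound 3 (0.09 log units; within the scatter). For compound 3 the expected value is 10000 nM, with an estimated range of 3500 nM to 30000 nM.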

Compound 3, half-maximal inhibitory concentration: 12200 nM
For compound 3 the middle estimate is 1.2-fold (0.09 log units) below the measured one; low and high end bracket the measured number.
By their numbers in this assay, from the lowest: compounds 1, 3 and 2 (each within the scatter of the next).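

In this assay, the group of 12 heavy atoms, with one five-membered non-aromatic ring with 1 hetero atom and one five-membered non-aromatic ring with 2 hetero atoms, enters in place of a hydrogen atom on a saturated chain carbon bound to a carbonyl carbon and gives a 1.5-fold higher number from compound 1 to compound 3 (0.18 log units; within the scatter). The earlier pair had shown only an acetyl entering on an oxygen on an aromatic ring, so this is the first sign that this place accepts so large a group without a step beyond the scatter. Nothing available explains why the number holds here.

On these data alone, whether an amine or a carboxylic acid on the same chain, or a plain longer chain without the two rings, would also stay within the scatter remains open. So does the outcome of placing this group on the oxygen on an aromatic ring that carries the second acetyl in compound 2.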